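A few compounds are considered here, and "the series" means these few. Any claim that something is new, unique, unknown or untested is made for them only; others in the source may bear on it.

Measured in a functional assay on MCF7 cells (Homo sapiens) for inhibition, read by MTT assay, with a stated time of 72 h; a higher number here means a weaker inhibitor, a lower number a stronger inhibitor:
- Compound 1 `CC(C)c1ccc(NC(=O)C2CCN(C/C=C/c3ccccc3)CC2)cc1` gives 9100 nM
- Compound 2 `COc1ccc(NC(=O)C2CCN(C/C=C/c3ccccc3)CC2)cc1` gives > 100000 nM

Compound 2 sits at the limit of > 100000 nM in this assay, at which 1 of the 2 values shown sits, so its value is a limit and not a number. Compound 3 `COc1ccccc1NC(=O)C1CCN(C/C=C/c2ccccc2)CC1` has the same atoms, joined differently: 2-methoxyphenyl in place of 4-methoxyphenyl on an amide-type nitrogen. For the measured compounds named here, the only measured step bearing on this is an at least 10-fold higher number from compound 1 to compound 2 (1.04 log units; beyond the scatter), which is large but replaces a group rather than moving one. Since the methoxy group stays, compound 3 is expected to remain weak in this assay, with a modest move to a lower number or none beyond the scatter. The estimated step is an at least 2.0-fold lower number from compound 2 to compound 3 (0.30 log units; that floor lies within the scatter). Compound 3 is estimated at 50000 nM, with an expected range of 12000 nM to 100000 nM.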

Compound 3, half-maximal inhibitory concentration: > 100000 nM
Compound 3: no number, only a limit (the forecaster's own chance of this, stated with the estimate: 55%); at least 2.0-fold (0.30 log units) between middle value and limit.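

Compound 3 gives > 100000 nM in this assay, and that value is a limit, not a number. The step between compound 2 and compound 3 cannot be read, so this change on the amide-type nitrogen shows only that 2-methoxyphenyl, like 4-methoxyphenyl, gives no value inside the range of the assay. Compared with 4-isopropylphenyl, 2-methoxyphenyl gives an at least 10-fold higher number from compound 1 to compound 3 (1.04 log units; beyond the scatter), so both methoxy placements fall short of compound 1.

From the compounds shown here alone, whether either methoxyphenyl differs from the other beyond the limit remains open. So does whether 4-tert-butylphenyl or 4-chlorophenyl on the amide-type nitrogen would match compound 1.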